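The compounds below may be only part of what the source reports. "The series", "measured", "known", "first", "only" and "open" are said of these compounds alone.

Measured in a functional assay on OVCAR-5 cells (Homo sapiens) for inhibition, read by sulforhodamine B assay, with a stated time of 48 h; on this read-out higher numbers stand for weaker inhibition of growth and lower numbers for stronger inhibition of growth:
- Compound 1 `CN(C)/C=C/C(=O)c1nn(-c2ccccc2)c(-c2ccccc2)c1C#N`: > 100000 nM (a limit)
- Compound 2 `Cc1nnc(-c2nn(-c3ccccc3)c(-c3ccccc3)c2C#N)c2cn(-c3ccccc3)nc12`: > 100000 nM (a limit)
- Compound 3 `N#Cc1c(-c2nnc(-c3nn(-c4ccccc4)c(-c4ccccc4)c3C#N)c3nn(-c4ccccc4)cc23)nn(-c2ccccc2)c1-c1ccccc1`: 9120 nM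

Compound 2 gives a limit and not a number as its result. It stands at the limit of > 100000 nM in this assay, at which 2 of the 3 values shown sit. Compound 4 `N#Cc1c(-c2nnc(-c3ccccc3)c3nn(-c4ccccc4)cc23)nn(-c2ccccc2)c1-c1ccccc1` has phenyl in place of methyl on an aromatic carbon. For the measured compounds named here, no measured pair shows this change alone, so any expectation is tentative. Compound 3, at 9120 nM, is the only compound here with a number, so measurable inhibition is possible among these structures. In this assay, the expected at least 2.5-fold lower number from compound 2 to compound 4 (0.39 log units; beyond the scatter) is a moderate move towards stronger inhibition, and compound 4 may still report only a limit. The estimate for compound 4 is 40000 nM, within an expected range of 12000 nM to 100000 nM.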

Compound 4, concentration for 50% growth inhibition: > 100000 nM
Compound 4: no number, only a limit; the forecaster's own chance of this, stated with the estimate: 45%; at least 2.5-fold (0.39 log units) between middle value and limit.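

Compound 2 and compound 4 both report only a limit, and no step can be read between them for phenyl in place of methyl on an aromatic carbon. As far as these compounds go, whether this change alters growth inhibition stays open.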